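The source may report more compounds than this note shows. Statements on the series, on what has been measured and on what is new or still open speak of the compounds shown alone.

Working notes on the series, with values read in an ADME assay on Vero 76 cells (Chlorocebus sabaeus) for cytotoxicity, read by MTT assay, with a stated time of 96 h (a lower number here means that less compound is tolerated, a higher number that more compound is tolerated), and given in the list below.

- compound 1 `Cc1ccc(NCc2cn(-c3ccccc3)nc2-c2ccc(Cl)cc2)cc1` gives > 100000 nM (a limit, not a number)
- compound 2 `FC(F)(F)c1ccc(NCc2cn(-c3ccccc3)nc2-c2ccc(Cl)cc2)cc1` gives 18000 nM
- compound 3 `Clc1ccc(NCc2cn(-c3ccccc3)nc2-c2ccc(Cl)cc2)cc1` is not yet measured

Within the data shown here, compound 2 holds the only actual number so far (18000 nM). Among the measured compounds shown here, the one other reading is the limit of > 100000 nM in this assay, at which 1 of the 2 values shown sits, and it belongs to compound 1, so no wider ranking can be drawn.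

Going on to compound 3, the change is chloro in place of trifluoromethyl on an aromatic carbon and in words it is chloro in place of trifluoromethyl on an aromatic carbon, para to a large group. For the measured compounds named here, one measured step bears on this, since it touches the same place: an at least 5.5-fold lower number from compound 1 to compound 2 (0.74 log units; beyond the scatter) with trifluoromethyl in place of methyl. Going by the values given here, that step starts from a limit, and it is the only guide to the size of change at this place. Among the compounds with values here, it shows that the group here can move the number, but no measured step yet involves chloro. An estimated 1.4-fold higher number from compound 2 to compound 3 (0.14 log units; within the scatter) is therefore expected, leaning towards a higher number and not beyond the scatter, though a reading at the limit remains possible. Compound 3 is expected at 25000 nM (estimated range 10000 nM to 100000 nM).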

Compound 3, half-maximal cytotoxic concentration: 90000 nM
Beside the measured number, compound 3's estimate is 3.6-fold (0.56 log units) below it; the range from low to high includes it.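

In this assay, chloro in place of trifluoromethyl gives a 5.0-fold higher number from compound 2 to compound 3 (0.70 log units; beyond the scatter), so the change at this position is now seen between two measured numbers and not only from a limit. Compound 2 now has a clearly lower number than both compound 1 and compound 3, which makes trifluoromethyl the only one of the three groups shown here to stand apart, with no compound going against this. Chloro in place of methyl gives an at least 1.1-fold lower number from compound 1 to compound 3 (0.04 log units; that floor lies within the scatter), and as that floor lies within the scatter, no order can be stated between these two compounds, because compound 1 carries a limit and not a number: the limit of > 100000 nM in this assay, at which 1 of the 3 values shown sits.

From the compounds shown here alone, whether the lower number belongs to trifluoromethyl alone or would also appear with other groups at this position, such as a nitrile, a methoxy group, an amine or a carboxylic acid, remains open. Also open, going by these compounds, is whether the same gap between trifluoromethyl and chloro would hold with the rest of the shared core changed, since all three compounds differ only at this one position.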